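A few compounds are considered here, and "the series" means these few. Any claim that something is new, unique, unknown or untested is made for them only; others in the source may bear on it.

Compound 3 `COc1ccc(NC(=O)NCCNS(=O)(=O)c2ccc(-c3ccccc3OCc3cccc(O)c3)s2)cc1` is one of three compounds whose cytotoxicity was examined in an ADME assay on HEK-293T cells (Homo sapiens) for cytotoxicity, read by CCK-8 assay, with a stated time of 48 h; on this read-out higher numbers stand for weaker inhibition and lower numbers for stronger inhibition. In this assay compound 3 gives > 20000 nM, which is a limit of the assay and not a number. Compound 1 `O=C(NCCNS(=O)(=O)c1ccc(-c2ccccc2OCc2cccc(O)c2)s1)Nc1cc(Cl)cc(Cl)c1` also sits at a limit; in this assay compound 1 gives > 20000 nM. Compound 2 `O=C(NCCNS(=O)(=O)c1ccc(-c2ccccc2Oc2ccc([N+](=O)[O-])c([N+](=O)[O-])c2)s1)Nc1ccc(Cl)cc1` reaches a limit as well; in this assay compound 2 gives > 20000 nM. Compound 3 therefore stands where every measured compound stands, at the limit of > 20000 nM in this assay, at which 3 of the 3 values shown sit. Going by the values given here, the one step measured in a single place, a step that the two limits leave unreadable from compound 1 to compound 3, has no readable size; both of its ends rest on (the limit of > 20000 nM in this assay, at which 3 of the 3 values shown sit).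

Compound 4 `COc1ccc(NC(=O)NCCNS(=O)(=O)c2ccc(-c3ccccc3Oc3ccc([N+](=O)[O-])c([N+](=O)[O-])c3)s2)cc1` differs from compound 3 by 3,4-dinitrophenyl in place of 3-hydroxybenzyl on an oxygen on an aromatic ring. Among the compounds with values here, compound 2 carries the same 3,4-dinitrophenyl on an oxygen on an aromatic ring, but no step to it is measured here, and its own value shows only a limit. The measured steps thus give no direction and no size to expect in this assay beyond the scatter. Compound 4 is expected to give 25000 nM, with a range from 10000 nM to 60000 nM. The estimated step is a step that the limit leaves unreadable from compound 3 to compound 4, and the most likely outcome is once more a limit rather than a number.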

Compound 4, half-maximal inhibitory concentration: 18500 nM
Compound 4: middle estimate off by 1.4-fold (0.13 log units), on the high side; the measured number falls inside the stated range.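

In this assay, going by these compounds alone, compound 4 gives 18500 nM, the first reading in this set that is a number and not a limit, so a value can now be read with 3,4-dinitrophenyl on the oxygen on an aromatic ring. Setting that group in place of 3-hydroxybenzyl is an at least 1.0-fold lower number from compound 3 to compound 4 (0.03 log units; that floor lies within the scatter), and methoxy in place of chloro on an aromatic carbon is an at least 1.0-fold lower number from compound 2 to compound 4 (0.03 log units; that floor lies within the scatter), so neither change can yet be told apart from the scatter. The step between the other two compounds cannot be read, and the series as a whole still rests almost entirely on one limit: the limit of > 20000 nM in this assay, at which 3 of the 4 values shown sit.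

Going by these compounds, how large either change really is stays open, as the values on the far side of both steps are limits and not numbers. Also open, on these data alone, is what an amine or a carboxylic acid in place of 3,4-dinitrophenyl on that oxygen would give in this assay, and whether any such group would bring the reading clearly away from the limit.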